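Iodo in place of fluoro on the methoxy-bearing ring

The source may report more compounds than this note shows. Statements on the series, on what has been measured and on what is new or still open speak of the compounds shown alone.

Compound 1 `COc1ccc(-c2nc3ccccc3s2)cc1OC`: 52700 nM
Compound 2 `COc1ccc(-c2nc3cc(F)ccc3s2)cc1C`: 48 nM
Compound 3 `COc1ccc(-c2nc3cc(F)ccc3s2)cc1F`: 870 nM

All three compounds were tested in a functional assay on MCF7 cells (Homo sapiens) for antiproliferative activity (a lower number here means a stronger inhibitor of growth, a higher number a weaker inhibitor of growth), and compound 3 holds the middle place: its 870 nM is a higher number than compound 2 at 48 nM and a lower number than compound 1 at 52700 nM in the same test.

The next compound is compound 4 `COc1ccc(-c2nc3cc(F)ccc3s2)cc1I`, which has iodo in place of fluoro on an aromatic carbon, ortho to a methoxy group (iodo in place of fluoro on an aromatic carbon). For the measured compounds named here, no iodo compound has been measured yet, so only one step offers guidance. At this same place, the step of an 18-fold higher number from compound 2 to compound 3 (1.26 log units; beyond the scatter) shows that fluoro gave a much weaker result than methyl. Compound 1 differs in more than one place and says little here. Iodo is judged likelier to resemble methyl than fluoro, though this is a judgement and not a measurement, so a step toward a lower number is expected. The expected change is a 5.8-fold lower number from compound 3 to compound 4 (0.76 log units; beyond the scatter) in this assay, with real uncertainty. For compound 4 the estimated value is 150 nM, with an expected range from 25 nM to 900 nM.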

Compound 4, concentration for 50% growth inhibition: 820 nM
Beside the measured number, compound 4's estimate is 5.5-fold (0.74 log units) below it; the range from low to high includes it.
By their numbers in this assay, from the lowest: compound 2; then compounds 4 and 3 (each within the scatter of the next); then compound 1.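

In this assay, iodo in place of fluoro on this aromatic carbon gives a 1.1-fold lower number from compound 3 to compound 4 (0.03 log units; within the scatter), so the two halogens cannot be told apart at this place. Iodo in place of methyl gives a 17-fold higher number from compound 2 to compound 4 (1.23 log units; beyond the scatter), so of the three groups tried here, methyl alone stands apart, with fluoro and iodo together on the side of the higher numbers. Nothing at hand explains why methyl differs from the two halogens.

The compounds shown leave open whether any other group can match methyl at this place, such as a longer chain like ethyl, an amine or a nitrile. They also leave open what the fluoro on the core contributes, since compound 1 differs from the others in more than one place.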